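This account rests on a few compounds, and the source may have more. Where it says the series, first, only, none or still open, it means among the compounds named here.

Among the compounds with values here, in a functional assay on HT-29 cells (Homo sapiens) for inhibition, read by luminescence and CellTiter-Glo, with a stated time of 24 h (on this read-out lower numbers stand for an effect already at smaller amounts and higher numbers for an effect only at larger amounts of compound), compound 1 `CN1C(=S)[C@@H](NC(=O)c2nc(Cc3ccccc3)n(C3CCC3)n2)COc2ccccc21` gives 181 nM, while compound 2 `CN1C(=S)[C@@H](NC(=O)c2nc(Cc3ccccc3)n(C3COC3)n2)COc2ccccc21` gives 916 nM, the higher of the two numbers measured so far. Compound 3 `CN1C(=S)[C@@H](NC(=O)c2nc(Cc3ccccc3)n(CC3COC3)n2)COc2ccccc21` has not yet been measured. It carries (oxetan-3-yl)methyl in place of oxetan-3-yl on the same aromatic nitrogen: (oxetan-3-yl)methyl in place of oxetan-3-yl on an aromatic nitrogen. Within the data shown here, the only measured step at this nitrogen is a 5.1-fold higher number from compound 1 to compound 2 (0.70 log units; beyond the scatter), for oxetan-3-yl in place of cyclobutyl. Among the measured compounds shown here, that modest step, beyond the scatter, exchanges one group for another and offers only an indirect guide, since no measured compound carries (oxetan-3-yl)methyl. A step smaller than that one is therefore expected in this assay, probably toward a slightly lower number and not beyond the scatter. The estimated change is a 1.5-fold lower number from compound 2 to compound 3 (0.18 log units; within the scatter). For compound 3 the expected value is 600 nM, with an estimated range of 170 nM to 2000 nM.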

Compound 3, half-maximal effective concentration: 2830 nM
For compound 3 the middle estimate is 4.7-fold (0.67 log units) below the measured one; the measured number lies above the stated range.
By their numbers in this assay, from the lowest: compound 1; then compound 2; then compound 3.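

In this assay the change to (oxetan-3-yl)methyl gives a 3.1-fold higher number from compound 2 to compound 3 (0.49 log units; beyond the scatter) even though the four-membered ring with its one hetero atom stays and the group goes only from 4 to 5 heavy atoms. This position therefore responds to more than an exchange of one ring for another. Measured against the cyclobutyl group, the same change amounts to a 16-fold higher number from compound 1 to compound 3 (1.19 log units; beyond the scatter) and is the largest step among these compounds, though nothing measured here accounts for either step.

The compounds shown leave open how a cyclobutylmethyl group on this aromatic nitrogen would compare with the cyclobutyl of compound 1 and with the (oxetan-3-yl)methyl of compound 3. They also leave open how an amine or a carboxylic acid at the end of a longer chain would read at this nitrogen.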